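The source may report more compounds than this note shows. Statements on the series, on what has been measured and on what is new or still open speak of the compounds shown alone.

Measured so far in an ADME assay on KB cells (Homo sapiens) for cytotoxicity; a lower number here means that less compound is needed, a higher number that more compound is needed for the effect:
compound 1, `COc1cc2c(c(OC)c1OC)C(=O)[C@]1(OC)C=C[C@H]2N(C(=O)OCC(C)C)N1C(=O)OCC(C)C` — > 300 ug/mL
compound 2, `CCOC(=O)N1[C@@H]2C=C[C@@](OC)(C(=O)c3c2cc(OC)c(OC)c3OCc2ccccc2F)N1C(=O)OCC` — 99.7 ug/mL
compound 3, `CCOC(=O)N1[C@@H]2C=C[C@@](OC)(C(=O)c3c2cc(OC)c(OC)c3OCc2ccc(Cl)cc2)N1C(=O)OCC` — for compound 3 the reading is 99.9 ug/mL.

For compound 1 the reading > 300 ug/mL is a limit of this assay, not a number. Within the data shown here, compound 2 gives 99.7 ug/mL and compound 3 gives 99.9 ug/mL; the only measured step, a 1.0-fold higher number from compound 2 to compound 3 (0.00 log units; within the scatter), lies within the scatter. Compound 4, `COc1cc2c(c(OCc3ccccc3F)c1OC)C(=O)[C@]1(OC)C=C[C@H]2N(C(=O)OCC(C)C)N1C(=O)OCC(C)C`, is not yet measured; it differs from compound 1 by 2-fluorophenyl in place of hydrogen on a saturated chain carbon bound to an oxygen on an aromatic ring. Among the measured compounds shown here, no measured step matches this change, and compounds 2 and 3 differ from compound 1 in more than one place, so their numbers are only a loose guide. Still, a lower number is expected, roughly an at least 3.0-fold lower number from compound 1 to compound 4 (0.47 log units; beyond the scatter). Compound 4 is therefore estimated at 100 ug/mL, within 40 ug/mL to 300 ug/mL.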

Compound 4, concentration for half-maximal effect: 109 ug/mL
Beside the measured number, compound 4's estimate is 1.1-fold (0.04 log units) below it; measured number inside the range.
By their numbers in this assay, from the lowest: compounds 2, 3 and 4 (each within the scatter of the next). At a limit, above all of these: compound 1.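

Among these compounds, compounds 2 and 3 differ from compound 1 in more than one place, so compound 4 gives the first direct reading of this position, a saturated chain carbon bound to an oxygen on an aromatic ring. In this assay, 2-fluorophenyl in place of hydrogen there, which turns methoxy into (2-fluorobenzyl)oxy, gives an at least 2.7-fold lower number from compound 1 to compound 4 (0.43 log units; beyond the scatter). The true size of this step stays unknown, since compound 1 stands at a limit of the assay: the limit of > 300 ug/mL in this assay, at which 1 of the 4 values shown sits.

Going by these compounds, whether a smaller group such as ethyl at this place would also lower the number remains open. So does the effect of an amine or a carboxylic acid there.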